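Removing a Chloro From Compound 1: What Compound 3 May Show

The source may report more compounds than this note shows. Statements on the series, on what has been measured and on what is new or still open speak of the compounds shown alone.

Measured so far in a functional assay on RPMI-8226 cells (Homo sapiens) for cytotoxicity, read by sulforhodamine B assay, with a stated time of 48 h; a higher number here means that more compound is tolerated, a lower number that less compound is tolerated:
compound 1 `ClCc1cccc(Cn2cnc3c(Cl)nc(Cl)nc32)c1`: > 100000 nM.
compound 2 `ClCc1ccccc1Cn1cnc2ncnc(Cl)c21`: 50100 nM.

For compound 1 only a limit is known in this assay, namely > 100000 nM, so its position on the scale cannot be fixed. Compound 2 gives 50100 nM in this assay, a number rather than a limit. Going by the values given here, no step between two measured compounds that differ in a single place is available, so no measured step can guide the next one directly.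

Compound 3 `ClCc1cccc(Cn2cnc3c(Cl)ncnc32)c1` differs from compound 1 in one place: hydrogen in place of chloro on an aromatic carbon. Since compound 1 sits at the limit of > 100000 nM in this assay, at which 1 of the 2 values shown sits, only a move toward less tolerated compound could be seen as a change. Compound 3 is expected to tolerate somewhat less compound than compound 1, with an expected step of an at least 1.4-fold lower number from compound 1 to compound 3 (0.15 log units; that floor lies within the scatter), though the true step may stay within the scatter. The estimate for compound 3 in this assay is 70000 nM, with a range from 25000 nM to 200000 nM.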

Compound 3, concentration lethal to 50% of the cells: 87100 nM
Compound 3: middle estimate off by 1.2-fold (0.09 log units), on the low side; the measured number falls inside the stated range.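

In this assay, going by these compounds alone, this is the first reading of a change at the aromatic carbon between two ring nitrogen atoms: hydrogen in place of chloro gives an at least 1.1-fold lower number from compound 1 to compound 3 (0.05 log units; that floor lies within the scatter), so no shift beyond the scatter can be claimed. Compound 3 gives a number rather than a limit, 87100 nM, which fixes a position on the scale for this hydrogen-bearing compound. Compound 1 is held only by a limit, so the step is a floor and its true size cannot be read, because of where that compound sits: the limit of > 100000 nM in this assay, at which 1 of the 3 values shown sits.

Going by these compounds, whether an amine or a methoxy group at this position would give a number apart from that of compound 3 remains open. Also open, on these data alone, is what the remaining chloro group, meta to this position, contributes to the read-out.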